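Notes on the fluorophenyl ring on the aromatic nitrogen

This account rests on a few compounds, and the source may have more. Where it says the series, first, only, none or still open, it means among the compounds named here.

Measured so far:
compound 1, `Cc1cc(=O)n(-c2ccc(Br)cc2F)nc1C(=O)Nc1ccc(Oc2ncnc3sccc23)cc1`, gives 6300 nM in a functional assay on HepG2 cells (Homo sapiens) for cytotoxicity, read by MTT assay, with a stated time of 72 h; a lower number here means a stronger inhibitor, a higher number a weaker inhibitor
compound 2, `Cc1cc(=O)n(-c2cccc(F)c2)nc1C(=O)Nc1ccc(Oc2ncnc3sccc23)cc1`, gives 18500 nM

Compound 2 holds the highest of the two numbers; the nearest is compound 1, with a 2.9-fold higher number from compound 1 to compound 2 (0.47 log units; beyond the scatter). Compound 3, `Cc1cc(=O)n(-c2ccc(F)c(F)c2)nc1C(=O)Nc1ccc(Oc2ncnc3sccc23)cc1`, differs from compound 2 by fluoro in place of hydrogen on an aromatic carbon. For the measured compounds named here, the only step bearing on it is a 2.9-fold higher number from compound 1 to compound 2 (0.47 log units; beyond the scatter), where 3-fluorophenyl in place of 4-bromo-2-fluorophenyl raised the number modestly. Putting a halogen back para to the large group is expected to move the number part of the way toward compound 1, so a modest lower number is expected: a 1.9-fold lower number from compound 2 to compound 3 (0.27 log units; within the scatter). Compound 3 is estimated at 10000 nM, range 4000 nM to 25000 nM.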

Compound 3, half-maximal inhibitory concentration: 16800 nM
Estimate against measurement, compound 3: 1.7-fold (0.23 log units) below; the measured number falls inside the stated range.
By their numbers in this assay, from the lowest: compound 1; then compounds 3 and 2 (each within the scatter of the next).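

In this assay, fluoro on this aromatic carbon, para to a large group and ortho to a fluoro group, reads as a 1.1-fold lower number from compound 2 to compound 3 (0.04 log units; within the scatter), so compound 2 and compound 3 cannot be told apart here. The 3,4-difluorophenyl ring still leaves a 2.7-fold higher number from compound 1 to compound 3 (0.43 log units; beyond the scatter), so fluoro at this carbon does not match the number of compound 1. Nothing at hand accounts for either step. Still open, as far as these compounds go, is which feature of the 4-bromo-2-fluorophenyl ring carries that gap, and whether a bromo, methoxy or amine group on this carbon would shift the number.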